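The compounds below may be only part of what the source reports. "The series", "measured", "known", "first", "only" and "open" are said of these compounds alone.

Working notes on the series. In a functional assay on SF-539 cells (Homo sapiens) for inhibition, read by sulforhodamine B assay, with a stated time of 48 h (on this read-out lower numbers stand for stronger inhibition of growth and higher numbers for weaker inhibition of growth), compound 1 `COc1ccc(-c2[nH]c3ccccc3c2/C=C(\C#N)S(=O)(=O)c2ccccc2)cc1` gives 299 nM, the lowest of the three numbers in hand. Compound 2 `COc1ccc2[nH]c(-c3ccccc3)c(C=C(C#N)C#N)c2c1` gives 2900 nM in this assay, a higher number that lies beyond the scatter, and compound 3 `CCOC(=O)C(=Cc1c(-c2ccccc2)[nH]c2ccccc12)C(=O)OCC` gives 14500 nM, the highest of the three, also beyond the scatter. No pair among these three differs in a single place, so none of them shows what one isolated change does on this read-out. Compound 4 `COc1ccc(-c2[nH]c3ccc(OC)cc3c2/C=C(\C#N)S(=O)(=O)c2ccccc2)cc1` is the untested member: it differs from compound 1 by methoxy in place of hydrogen on an aromatic carbon. With nothing in the measured set isolating such a change, the expectation for compound 4 is a small step, in no clear direction, not beyond the scatter. The estimated step is a 1.2-fold higher number from compound 1 to compound 4 (0.07 log units; within the scatter). Compound 4 is therefore expected to give 350 nM, with a range from 120 nM to 1000 nM.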

Compound 4, concentration for 50% growth inhibition: 510 nM
The estimate for compound 4 lay 1.5-fold (0.16 log units) below the measured number; low and high end bracket the measured number.
By their numbers in this assay, from the lowest: compounds 1 and 4 (each within the scatter of the next); then compound 2; then compound 3.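

In this assay, the series now has its first single-place comparison: a 1.7-fold higher number from compound 1 to compound 4 (0.23 log units; within the scatter), for methoxy in place of hydrogen on an aromatic carbon of the six-membered aromatic ring of carbon only, part of the fused system of two rings. This position therefore takes methoxy with a step that stays within the scatter, so compound 1 and compound 4 cannot be told apart on this read-out. Nothing on hand bears on the reason for this result.

The compounds shown leave open whether a carboxylic acid, an amine or a longer alkoxy chain at the same carbon would also stay within the scatter. They also leave open whether methoxy in place of hydrogen would give a similar step on the other parts of the shared core.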